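The source may report more compounds than this note shows. Statements on the series, on what has been measured and on what is new or still open speak of the compounds shown alone.

In a functional assay (trachea) with Cavia porcellus as the target (a lower number here means that less compound is needed, a higher number that more compound is needed for the effect), compound 1 `CCCn1c(=O)n(CCC(=O)O)c(=O)c2[nH]cnc21` gives 21200 nM and compound 2 `CCCn1c(=O)n(CCC(N)=O)c(=O)c2[nH]cnc21` gives 13100 nM while compound 3 `CCCn1c(=O)n(CCN(C)C)c(=O)c2[nH]cnc21` gives 2700 nM as the lowest of the three numbers. Compound 4 `CCCn1c(=O)n(CC(C)=O)c(=O)c2[nH]cnc21` remains unmeasured. The change from compound 3 is acetyl in place of (dimethylamino)methyl on a saturated chain carbon bound to an aromatic nitrogen and so places acetyl in place of (dimethylamino)methyl on a saturated chain carbon bound to an aromatic nitrogen. The closest evidence is a 4.9-fold lower number from compound 2 to compound 3 (0.69 log units; beyond the scatter) and a 7.9-fold lower number from compound 1 to compound 3 (0.89 log units; beyond the scatter) with both steps modest but beyond the scatter, whereas a 1.6-fold lower number from compound 1 to compound 2 (0.21 log units; within the scatter) stays within it. For the measured compounds named here, no measured compound carries the acetyl group, so a modest rise is expected on leaving the dimethylamino end. The estimated change is a 3.3-fold higher number from compound 3 to compound 4 (0.52 log units; beyond the scatter) in this direction. Compound 4 is estimated at 9000 nM and expected between 3000 nM and 25000 nM.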

Compound 4, half-maximal effective concentration: 14900 nM
The estimate for compound 4 lay 1.7-fold (0.22 log units) below the measured number; low and high end bracket the measured number.
By their numbers in this assay, from the lowest: compound 3; then compounds 2, 4 and 1 (each within the scatter of the next).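

In this assay the exchange of (dimethylamino)methyl for acetyl gives a 5.5-fold higher number from compound 3 to compound 4 (0.74 log units; beyond the scatter) and so shows that a neutral-count swap of this kind at this place does not keep the low number of compound 3. The other two comparisons give a 1.1-fold higher number from compound 2 to compound 4 (0.06 log units; within the scatter) and a 1.4-fold lower number from compound 1 to compound 4 (0.15 log units; within the scatter) and so leave acetyl, carbamoylmethyl and carboxymethyl indistinguishable here, with compound 3 alone standing apart. Nothing available here accounts for this difference. The compounds shown leave open whether the low number needs the dimethylamino group specifically or would also appear with a primary amine or with a longer chain ending in dimethylamino.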